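A Methylpyridyl Amide on the Shared Core

The source may hold more compounds than are shown below. What is called first, only, known or untested is meant among the compounds shown, and "the series" means these compounds.

Compound 2 `O=C(Nc1nnc(-c2ccc3c(c2)OCCO3)s1)c1ccncc1` carries pyridin-4-yl on the carbonyl carbon of the shared core. In a functional assay on HepG2 cells (Homo sapiens) for antiproliferative activity, read by MTT assay, with a stated time of 48 h (on this read-out lower numbers stand for an effect already at smaller amounts and higher numbers for an effect only at larger amounts of compound), compound 2 reaches only the limit > 100 ug/mL, so its standing is known as a limit and not as a number. Compound 1 `O=C(Nc1nnc(-c2ccc3c(c2)OCCO3)s1)c1ccc(Cl)nc1` differs from it only in the ring on that carbonyl carbon, and in this assay compound 1 gives 15.4 ug/mL. For the measured compounds named here, the one step at hand, an at least 6.4-fold higher number from compound 1 to compound 2 (0.81 log units; beyond the scatter), rests on (the limit of > 100 ug/mL in this assay, at which 1 of the 2 values shown sits). Compound 3 `Cc1ccc(C(=O)Nc2nnc(-c3ccc4c(c3)OCCO4)s2)cn1` has not been measured; it changes compound 2 by 6-methylpyridin-3-yl in place of pyridin-4-yl on a carbonyl carbon, which returns to the pyridin-3-yl pattern of compound 1 with methyl where compound 1 has chloro. Since the step of an at least 6.4-fold higher number from compound 1 to compound 2 (0.81 log units; beyond the scatter) was at least modest, the change in compound 3 is expected to lower the number, with an at least 4.0-fold lower number from compound 2 to compound 3 (0.60 log units; beyond the scatter) estimated. Compound 3 is estimated at 25 ug/mL, between 8 ug/mL and 100 ug/mL.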

Compound 3, half-maximal effective concentration: > 100 ug/mL
Compound 3: no number, only a limit; the forecaster's own chance of this, stated with the estimate: 30%; middle value at least 4.0-fold (0.60 log units) from the limit.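

Compound 3 isolates the group on the aromatic carbon, since it keeps the pyridin-3-yl pattern of compound 1 and changes only chloro to methyl. In this assay this gives an at least 6.4-fold higher number from compound 1 to compound 3 (0.81 log units; beyond the scatter), so among the compounds shown, the pyridin-3-yl pattern alone does not bring back a readable number, and only compound 1, with chloro, gives one. How 6-methylpyridin-3-yl compares with pyridin-4-yl cannot be read, because compound 2 and compound 3 both rest on a limit of the assay: the limit of > 100 ug/mL in this assay, at which 2 of the 3 values shown sit.

As far as these compounds go, it remains open whether fluoro, bromo, methoxy or an amine in place of chloro on that aromatic carbon would give a number. From the compounds shown here alone, it also remains open how chloro would fare on pyridin-4-yl, and how far compound 2 and compound 3 lie from the limit.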